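The source may report more compounds than this note shows. Statements on the series, on what has been measured and on what is new or still open speak of the compounds shown alone.

Three related compounds have been measured in a functional assay on NCI-H522 cells (Homo sapiens) for inhibition, read by colorimetric assay, with a stated time of 3 days; on this read-out higher numbers stand for weaker inhibition and lower numbers for stronger inhibition. Compound 1 `COc1ccc(-c2cnc(NC(=O)CCCCCCNC(=O)C(O)(O)C(F)(F)F)s2)cc1` gives 3240 nM, compound 2 `O=C(CCCCCCNC(=O)C(O)(O)C(F)(F)F)Nc1ncc(-c2ccc(Br)cc2)s1` gives 2700 nM, and compound 3 `COc1ccc2sc(NC(=O)CCCCCCNC(=O)C(O)(O)C(F)(F)F)nc2c1`, built on a different core, gives 3230 nM. Compound 2 therefore stands level with the other two, its value within the scatter of both.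

Compound 4 `O=C(CCCCCCNC(=O)C(O)(O)C(F)(F)F)Nc1ncc(-c2ccc(O)cc2)s1` has not yet been measured. It differs from compound 2 in a single place: hydroxy in place of bromo on an aromatic carbon. Among the measured compounds shown here, one measured step bears on this change: a 1.2-fold lower number from compound 1 to compound 2 (0.08 log units; within the scatter), with bromo in place of methoxy on an aromatic carbon. That step lies within the scatter. For the measured compounds named here, compound 3 offers no direct comparison, and no compound carrying hydroxy has been measured, so the evidence for this exchange is thin. The expectation rests on compound 2 at 2700 nM and on that one small step, and it is for no change beyond the scatter in this assay. The estimated size is a 1.1-fold higher number from compound 2 to compound 4 (0.05 log units; within the scatter). Compound 4 is expected at 3000 nM, with an estimated range from 1300 nM to 7000 nM.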

Compound 4, half-maximal inhibitory concentration: 1900 nM
The estimate for compound 4 lay 1.6-fold (0.20 log units) above the measured number; the measured number falls inside the stated range.
By their numbers in this assay, from the lowest: compounds 4, 2, 3 and 1 (each within the scatter of the next).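

In this assay the exchange of 4-bromophenyl for 4-hydroxyphenyl gives a 1.4-fold lower number from compound 2 to compound 4 (0.15 log units; within the scatter), and removing the methyl from the oxygen gives a 1.7-fold lower number from compound 1 to compound 4 (0.23 log units; within the scatter), so neither change moves the number beyond the scatter. With the earlier step of a 1.2-fold lower number from compound 1 to compound 2 (0.08 log units; within the scatter), bromo, methoxy and hydroxy have now all been compared on this aromatic carbon, para to a large group, and all three steps among them lie within the scatter; even the arrival of a hydrogen-bond donor and a hydrogen-bond acceptor, where bromo has neither, brings no change that can be told from repeat variation. No measurement shown here accounts for this flat picture, and any explanation of it would go beyond the data.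

On these data alone, it remains open whether an amine or a carboxylic acid on the same aromatic carbon would shift the number beyond the scatter, or whether this position would stay as flat with a larger group there. Also open, as far as these compounds go, is whether a longer chain in the shared side arm would change the number in this assay while the 4-hydroxyphenyl group is kept.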